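This account rests on a few compounds, and the source may have more. Where it says the series, first, only, none or still open, it means among the compounds named here.

Working notes on the series. In an ADME assay on Huh-7 cells (Homo sapiens) for cytotoxicity, read by MTT assay (a higher number here means that more compound is tolerated, a lower number that less compound is tolerated), compound 1 `CC(C)(C)C(=O)N(CCCCCCN1C[C@H](O)[C@@H](O)[C@H](O)[C@H]1CO)C1CCCCC1` gives 500000 nM. Compound 2 `CC(C)(C)C(=O)N(CCCCCCN1C[C@H](O)[C@@H](O)[C@H](O)[C@H]1CO)c1ccc(F)cc1F` reaches only a limit, > 500000 nM, with no number beyond it. The step of a number no lower from compound 1 to compound 2 (the limit leaves the size open) is therefore of open size. Compound 3 `CC(C)(C)C(=O)N(CCCCCCN1C[C@H](O)[C@@H](O)[C@H](O)[C@H]1CO)C1CC1` has "not determined" (no result reported) in this assay, so it stands nowhere on the numbers shown, and the record for this readout rests on the limit of > 500000 nM in this assay, at which 1 of the 3 values shown sits, together with the one number from compound 1. Compound 4 `CC(C)(C)C(=O)N(CCCCCCN1C[C@H](O)[C@@H](O)[C@H](O)[C@H]1CO)C1CCCCCC1` differs from compound 3 by cycloheptyl in place of cyclopropyl on an amide-type nitrogen. Among the measured compounds shown here, no measured step covers this change; the nearest point of reference is compound 1 with 500000 nM. Compound 4 is expected to give about 400000 nM in this assay, with a range from 150000 nM to 600000 nM.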

Compound 4, half-maximal cytotoxic concentration: > 500000 nM
Compound 4: no number, only a limit; the forecaster's own chance of this, stated with the estimate: 40%; middle value at least 1.2-fold (0.09 log units) from the limit.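

Compound 4 gives only a limit in this assay, not a number. Cycloheptyl in place of cyclohexyl gives a number no lower from compound 1 to compound 4 (the limit leaves the size open), while the step between the two limits cannot be read. At this place on the amide-type nitrogen, a seven-membered carbon ring and 2,4-difluorophenyl now both end at the same limit: the limit of > 500000 nM in this assay, at which 2 of the 4 values shown sit.

On these data alone, how far compound 2 and compound 4 lie past that limit stays open, and compound 3 still gives no point of comparison. Also open, as far as these compounds go, is what an amine or a carboxylic acid would give on this nitrogen.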